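Adding a chloro group to compound 2

A few compounds are considered here, and "the series" means these few. Any claim that something is new, unique, unknown or untested is made for them only; others in the source may bear on it.

Compound 1 `CCCC(=O)Oc1c(OC)c(OC)c(OC(=O)CCC)c2ccccc12` measured 4.64
Compound 2 `CC(=O)Oc1c(Oc2ccccc2)c(Oc2ccccc2)c(OC(C)=O)c2ccccc12` measured 4.8

In a physicochemical assay for lipophilicity (a higher number here means a more lipophilic compound, a lower number a more polar compound), compound 2 stands at 4.8 and lies within the usual scatter of compound 1, so these two values cannot be told apart. Compound 3 `CC(=O)Oc1c(Oc2ccccc2)c(Oc2ccccc2)c(OC(C)=O)c2cc(Cl)ccc12` has chloro in place of hydrogen on an aromatic carbon and otherwise matches compound 2. Among the compounds with values here, no measured pair shows this change, so its size is a judgement from the structural change alone. In this assay an upward step of a number 0.60 log units higher from compound 2 to compound 3 (beyond the scatter) is expected and would lie beyond the scatter. For compound 3 the estimated value is 5.4 with an expected range from 5 to 5.8 (not yet measured).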

Compound 3, partition coefficient: 5.6
Compound 3: middle estimate off by 0.20 log units, on the low side; the range from low to high includes it.
By their numbers in this assay, from the lowest: compounds 1 and 2 (each within the scatter of the next); then compound 3.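

In this assay, chloro in place of hydrogen on an aromatic carbon gives a number 0.80 log units higher from compound 2 to compound 3 (beyond the scatter), so this single-atom change moves the number beyond the scatter. Within the data shown here, it is the only change in one place that can be read so far, so it shows the effect of chloro at this position on this core alone. Nothing available explains the size of this step.

From the compounds shown here alone, whether fluoro, methoxy or an amine at this position would give a similar step remains open. So does the step for chloro on another aromatic carbon.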